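The compounds below may be only part of what the source reports. "The series", "measured", "known", "first", "only" and "open" are said of these compounds alone.

Measured so far:
- Compound 1 `O=C1/C(=C/c2ccccc2F)CN(S(=O)(=O)c2ccccc2)C/C1=C\c1ccccc1F`: 15900 nM
- Compound 2 `O=C1/C(=C/c2ccc(F)cc2)CN(S(=O)(=O)c2ccc(O[N+](=O)[O-])cc2)C/C1=C\c1ccc(F)cc1`: 5400 nM

Both compounds were tested in a functional assay on HepG2 cells (Homo sapiens) for cytotoxicity, read by MTT assay, with a stated time of 24 h; on this read-out lower numbers stand for stronger inhibition and higher numbers for weaker inhibition. Compound 1 gives 15900 nM and compound 2 gives 5400 nM; of the two numbers, that of compound 2 is the lower, and the gap between them is beyond the usual scatter of this assay, so compound 2 is the stronger of the pair. The two compounds differ in more than one place, so no single change can be read from that gap.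

Compound 3 `CC(=O)Nc1ccc(S(=O)(=O)N2C/C(=C\c3ccc(F)cc3)C(=O)/C(=C/c3ccc(F)cc3)C2)cc1` has not been measured. It differs from compound 2 in one place only: acetamido in place of nitrooxy on an aromatic carbon. Within the data shown here, no measured pair shows this change alone, so the direction and size of its effect are open. The estimate for compound 3 in this assay is 9000 nM, with a range from 3000 nM to 27000 nM; this amounts to an expected step of a 1.7-fold higher number from compound 2 to compound 3 (0.22 log units; within the scatter), modest and of uncertain direction.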

Compound 3, half-maximal inhibitory concentration: 7400 nM
Beside the measured number, compound 3's estimate is 1.2-fold (0.09 log units) above it; low and high end bracket the measured number.
By their numbers in this assay, from the lowest: compounds 2 and 3 (each within the scatter of the next); then compound 1.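

In this assay, among these compounds, the first single-change comparison at this position is acetamido in place of nitrooxy on an aromatic carbon, para to a large group, and it gives a 1.4-fold higher number from compound 2 to compound 3 (0.14 log units; within the scatter). Acetamido brings a hydrogen-bond donor that nitrooxy lacks, yet this assay does not separate the two groups, so in this pair the cytotoxicity reading does not depend on having nitrooxy at this position. Nothing measured here gives a reason for this result.

Still open, going by these compounds, is whether a different group at this position, such as an amine, a carboxylic acid or a longer chain, would stand apart from these two. Also open, on these data alone, is what a plain hydrogen at this position would give with the rest of compound 2 kept the same.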